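A few compounds are considered here, and "the series" means these few. Any claim that something is new, unique, unknown or untested is made for them only; others in the source may bear on it.

Of the compounds shown here, two measured so far share one core and differ only in the group attached to the amide nitrogen. Compound 1 `COc1nc2ccccc2nc1C(=O)Nc1ccc(C)cc1` carries a 4-methylphenyl there, and in an assay for antagonist activity at 5-hydroxytryptamine receptor 3A (Cavia porcellus), with a stated time of 10 min (a higher number here means weaker binding, a lower number tighter binding), compound 1 gives 50.1 nM. Compound 2 `COc1nc2ccccc2nc1C(=O)Nc1nc2ccccc2s1` carries a different group at the same position, and in this assay compound 2 gives 39.8 nM. These two values lie within the usual scatter of each other, so nothing separates them with confidence.

Compound 3 `CCCCNC(=O)c1nc2ccccc2nc1OC` has not yet been measured. It departs from compound 1 in one place: butyl in place of 4-methylphenyl on an amide-type nitrogen. For the measured compounds named here, no measured pair shows what such an exchange does here, so the size and direction of the step rest on judgement alone. The step from compound 1 to compound 3 is expected to be a 3.0-fold higher number from compound 1 to compound 3 (0.48 log units; beyond the scatter), a modest move toward weaker binding with a wide margin either way. For compound 3 the estimated dissociation constant in this assay is 150 nM, expected to fall between 40 nM and 600 nM.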

Compound 3, dissociation constant: 20 nM
Compound 3: middle estimate off by 7.5-fold (0.88 log units), on the high side; measured number outside the range, below it.
By their numbers in this assay, from the lowest: compounds 3, 2 and 1 (each within the scatter of the next, the first and the last beyond it).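

In this assay, butyl in place of 4-methylphenyl on the amide-type nitrogen gives a 2.5-fold lower number from compound 1 to compound 3 (0.40 log units; beyond the scatter) and so moves binding in the tighter direction. This position therefore does not need the six-membered aromatic ring of compound 1 for binding in the nanomolar range: a chain with no ring and fewer heavy atoms does better in this one pair. No measurement on hand explains this gain.

A single exchange cannot show whether binding depends on chain length, so a shorter ethyl or a longer hexyl could tighten binding further or weaken it. It also leaves open how this position responds to a chain that carries an amine or a carboxylic acid, or to a ring without aromatic character, such as cyclohexyl.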